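The source may report more compounds than this note shows. Statements on the series, on what has been measured and on what is new or still open speak of the compounds shown alone.

Working notes on the series. Compound 1 `Cc1cc(S(=O)(=O)Nc2nc3ccccc3c(=O)n2N)c(S)cc1Cl` and compound 2 `Cc1cc(S(=O)(=O)Nc2nc3cc(-c4ccccc4)sc3c(=O)n2Cc2ccccc2)c(S)cc1Cl` carry the same sulfonamide-bearing aryl piece with its thiol, while compound 3 `Cc1cc(S(=O)(=O)Nc2nc3cc(-c4ccc(Cl)cc4)sc3c(=O)n2Cc2ccccc2)c(S)cc1Cl` has not yet been measured. In a functional assay on SF-268 cells (Homo sapiens) for inhibition (a lower number here means a stronger inhibitor of growth, a higher number a weaker inhibitor of growth), compound 1 gives 7200 nM. For compound 2 only a limit of the assay is known: in this assay compound 2 gives > 100000 nM, which is a limit and not a number. Of the two values shown, one thus sits at the limit of > 100000 nM in this assay, at which 1 of the 2 values shown sits, and compound 2 stands at that weak end of the numbers shown. Among the measured compounds shown here, no step between measured compounds differing in a single place is available, so the move from compound 2 to compound 3 has no measured precedent to lean on. The change itself is chloro in place of hydrogen on an aromatic carbon of a six-membered aromatic ring of carbon only, para to a large group. With compound 2 already at the limit, the step of a number no higher from compound 2 to compound 3 (the limit leaves the size open) is expected to be none beyond the scatter, and a limit is expected to be reported again. Compound 3 is therefore estimated at 100000 nM, in the range 30000 nM to 300000 nM.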

Compound 3, concentration for 50% growth inhibition: > 100000 nM
Compound 3 was reported as a limit; the forecaster's own chance of this, stated with the estimate: 70%; the middle value lies on the limit itself.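

In this assay, compound 2 and compound 3 both stand at a limit rather than at a number, so no step can be read between them: the limit of > 100000 nM in this assay, at which 2 of the 3 values shown sit.

The compounds shown leave open whether going from phenyl to 4-chlorophenyl changes growth inhibition at all, and in which direction.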